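From a Fluorine to a Chlorine on the Pendant Phenyl

The source may report more compounds than this note shows. Statements on the series, on what has been measured and on what is new or still open speak of the compounds shown alone.

Compound 1 `COc1ccc(-n2cc(Cn3c(=O)oc4ccccc43)nn2)cc1` is recorded in a functional assay on the whole organism (strain albino Wistar) for inhibition, with Rattus norvegicus as the target, read by paw edema, with stated times of 1 h and 5 h, at a dose of 0.05 mmol/kg by the oral route (on this read-out lower numbers stand for less inhibition and higher numbers for more inhibition at the one dose given (going by the name of the read-out)), only as "active" (no number reported), with no figure attached. For the measured compounds named here, compound 2 `Cc1ccc2c(c1)oc(=O)n2Cc1cn(-c2ccc(F)cc2)nn1` is therefore the one compound with a number: in this assay compound 2 gives 80.6%. Compound 3 `Cc1ccc2c(c1)oc(=O)n2Cc1cn(-c2ccccc2Cl)nn1` has not yet been measured. It differs from compound 2 in a single place: 2-chlorophenyl in place of 4-fluorophenyl on an aromatic nitrogen. Going by the values given here, no measured step of this kind exists to lean on, so no change beyond the usual scatter is expected, and the step of a number 5.6 percentage points lower from compound 2 to compound 3 (within the scatter) is estimated to stay small. Compound 3 is expected to give about 75%, most likely between 55% and 90%.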

Compound 3, a percentage reported as inhibition, in the whole organism at one dose (the size of the read-out at that dose, not a potency): 72.9%
Estimate against measurement, compound 3: 2.1 percentage points above; measured number inside the range.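

In this assay, for the compounds shown here, this is the first measured step at this position on the aromatic nitrogen: a number 7.7 percentage points lower from compound 2 to compound 3 (within the scatter). It shows that 2-chlorophenyl can stand in place of 4-fluorophenyl with no change beyond the usual scatter, although the halogen and its place on the phenyl ring differ together. No measured evidence here bears on this result.

Going by these compounds, the separate contributions of the halogen and its place remain open, and 4-chlorophenyl would help to separate them. On these data alone, whether a plain phenyl, or a phenyl carrying an amine or a carboxylic acid, would fit equally well also stays open.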